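The compounds below may be only part of what the source reports. "The series", "measured", "known", "first", "only" and "open" are said of these compounds alone.

Measured in an ADME assay on MDCK cells (Canis lupus familiaris) for cytotoxicity, read by MTT assay, with a stated time of 24 h; a higher number here means that more compound is tolerated, a lower number that less compound is tolerated:
- compound 1 `N#CCCN(Cc1cccs1)S(=O)(=O)c1cccc(F)c1`: > 205000 nM, a limit
- compound 2 `N#CCCN(Cc1cccs1)S(=O)(=O)c1ccc(Cl)cc1`: > 195000 nM, a limit
- compound 3 `N#CCCN(Cc1cccs1)S(=O)(=O)c1ccc(C#N)cc1`: > 201000 nM, a limit

The value of compound 2 in this assay is a limit and not a number: > 195000 nM. The two other measured compounds also give only limits, so none of the three has a readable value.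

Compound 4 `N#CCCN(Cc1cccs1)S(=O)(=O)c1ccc([N+](=O)[O-])cc1` carries nitro in place of chloro on an aromatic carbon, para to a large group: nitro in place of chloro on an aromatic carbon. The closest measured change is a step that the two limits leave unreadable from compound 2 to compound 3, which also replaces chloro on an aromatic carbon. The change of the sulfonyl aryl group, a step that the two limits leave unreadable from compound 1 to compound 2, bears on it less directly. Neither step has a size that can be read, so they set no measured size for the new change, but neither shows a readable loss of tolerance.

The expected step is an at least 1.0-fold lower number from compound 2 to compound 4 (0.01 log units; that floor lies within the scatter), estimated to lie within the scatter, with no direction expected. Compound 4 is estimated at 190000 nM, with an expected range from 100000 nM to 300000 nM, and the assay is expected to report it most likely as a limit.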

Compound 4, half-maximal cytotoxic concentration: > 189000 nM
Compound 4: no number, only a limit (the forecaster's own chance of this, stated with the estimate: 85%); the middle value lies beyond the limit too.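

In this assay compound 4 gives > 189000 nM, a limit and not a number. Compound 2 and compound 3 also give only limits, so neither step to compound 4 can be read. The compounds shown leave open whether nitro, chloro or cyano on the aromatic carbon makes any difference to the concentration tolerated.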